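Cyclopentylmethyl Ester in Place of Cyclopropylmethyl

The source may report more compounds than this note shows. Statements on the series, on what has been measured and on what is new or still open speak of the compounds shown alone.

Compound 1 `C=C(C)[C@H]1CC=C(C)[C@@]2(O)[C@@H]1[C@H](c1ccccc1Br)O[C@@H]2C(=O)OCC1CC1` was tested in a functional assay on KB3 cells (Homo sapiens) for antiproliferative activity, read by MTT assay, with a stated time of 96 h (a lower number here means a stronger inhibitor, a higher number a weaker inhibitor), where compound 1 gives 50000 nM. Among the compounds with values here, of the two numbers known, this is the higher one. Compound 3 `C=C(C)[C@H]1CC=C(C)C2=CO[C@@H](c3ccco3)[C@@H]21` gives 2000 nM in this assay, a lower number by a gap that lies beyond the scatter. Compound 2 `C=C(C)[C@H]1CC=C(C)[C@H]2[C@@H]1[C@H](c1ccccc1Br)O[C@@H]2C(=O)OCC` reaches only a limit of the assay, since compound 2 gives > 100000 nM. That reading rests on (the limit of > 100000 nM in this assay, at which 1 of the 3 values shown sits).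

Compound 4 `C=C(C)[C@H]1CC=C(C)[C@@]2(O)[C@@H]1[C@H](c1ccccc1Br)O[C@@H]2C(=O)OCC1CCCC1` differs from compound 1 in one place: cyclopentyl in place of cyclopropyl on a saturated chain carbon bound to an oxygen next to a carbonyl group. Within the data shown here, no measured pair in this set shows the same change, so the expectation rests on compound 1 alone. The step of a 1.3-fold lower number from compound 1 to compound 4 (0.10 log units; within the scatter) is expected to stay within the scatter, with no clear direction. In this assay compound 4 is therefore estimated at 40000 nM, with a range from 15000 nM to 110000 nM.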

Compound 4, half-maximal inhibitory concentration: > 100000 nM
Compound 4 gave a limit, no number; the forecaster's own chance of this, stated with the estimate: 20%; at least 2.5-fold (0.39 log units) between middle value and limit.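

In this assay compound 4 gives only a limit, > 100000 nM, so this change yields no number to set against compound 1. Cyclopentyl in place of cyclopropyl on a saturated chain carbon bound to an oxygen next to a carbonyl group is the first change at this place that can be read, and it appears as an at least 2.0-fold higher number from compound 1 to compound 4 (0.30 log units; that floor lies within the scatter): it gives no sign of a lower number, but its floor alone does not separate the two compounds. The reading therefore marks a limit, not a measured size of step: the limit of > 100000 nM in this assay, at which 2 of the 4 values shown sit.

The compounds shown leave open how a cyclobutylmethyl ester would read at this place, and whether any number would appear for it. They also leave open how a carboxylic acid or a benzyl ester there would compare with compound 1 in this assay.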